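This account rests on a few compounds, and the source may have more. Where it says the series, first, only, none or still open, it means among the compounds named here.

Compounds measured in a physicochemical assay for solubility, read by nephelometry, in phosphate buffer, at pH 7.4; on this read-out higher numbers stand for higher solubility and lower numbers for lower solubility:
- compound 1 `Cc1cc2ccccc2n1CCNC(=O)/C=C/c1ccc(OCCCN(C)C)cc1`: 306000 nM.
- compound 2 `COc1cc(/C=C/C(=O)NCCn2c(C)cc3ccccc32)cc(OC)c1`: < 25000 nM.
- compound 3 `COc1cc(/C=C/C(=O)NCCn2c(C)cc3ccccc32)cc(OC)c1OCCO`: 66000 nM.

The value of compound 2 is a limit of the assay and not a number. Among the two numbers shown, compound 3 stands lowest, with compound 1 giving the higher number, beyond the scatter. Going by the values given here, the one measured step, an at least 2.6-fold higher number from compound 2 to compound 3 (0.42 log units; beyond the scatter), rests on the limit of < 25000 nM in this assay, at which 1 of the 3 values shown sits, and concerns a 2-hydroxyethoxy in place of hydrogen on an aromatic carbon, a change of a different kind from the one now considered.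

Compound 4 `COc1cc(/C=C/C(=O)NCCn2c(C(F)(F)F)cc3ccccc32)cc(OC)c1OCCO` differs from compound 3 by trifluoromethyl in place of methyl on an aromatic carbon. Among the compounds with values here, no measured step involves an exchange of methyl for trifluoromethyl, so no step in this set bears on it, and the expectation rests on the size of the change alone: a modest downward step or none beyond the scatter is expected, a 1.9-fold lower number from compound 3 to compound 4 (0.28 log units; within the scatter). Compound 4 is therefore estimated at 35000 nM, within a range from 15000 nM to 80000 nM, with a real chance that this assay reports only a limit.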

Compound 4, solubility: 35000 nM
Estimate against measurement, compound 4: no gap at the digits printed, and the stated range covers the measured number.
By their numbers in this assay, from the lowest: compounds 4 and 3 (each within the scatter of the next); then compound 1. At a limit, below all of these: compound 2.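

In this assay, going by these compounds alone, the earlier compounds all carried methyl on this aromatic carbon of the five-membered aromatic ring, next to the ring nitrogen, so they showed nothing about a change at this place. Trifluoromethyl, with 4 heavy atoms in place of the 1 of methyl, gives a 1.9-fold lower number from compound 3 to compound 4 (0.28 log units; within the scatter), so at this place and with the rest of compound 3 kept, the exchange leaves the two compounds within the scatter of each other. Nothing shown gives a cause for this result.

As far as these compounds go, whether the exchange would read the same way on compound 1, with its dimethylamino-bearing chain in place of the substitution of compound 3, stays open. So does what a nitrile, a carboxylic acid or a primary amine on this same aromatic carbon would give in this assay.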